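The source may hold more compounds than are shown below. What is called first, only, known or untested is meant among the compounds shown, and "the series" means these compounds.

Measured compounds:
compound 1 `N#CC1=C(N)N(c2ccc(S(N)(=O)=O)cc2)C2=C(C(=O)CCC2)C1/C=C/c1ccccc1` — 10%
compound 2 `N#CC1=C(N)N(c2ccc(S(N)(=O)=O)cc2)C2=C(C(=O)CCC2)C1c1ccc([N+](=O)[O-])cc1` — 80%

In a functional assay on Ehrlich cells (Mus musculus) for antiproliferative activity, read by trypan blue exclusion, with a stated time of 2 h, tested at 25 ug/mL (on this read-out higher numbers stand for a stronger effect at the one concentration tested and lower numbers for a weaker effect), compound 2 gives 80%, the highest of the two numbers. Its nearest neighbour is compound 1, which gives 10%. Compound 3 `N#CC1=C(N)N(c2ccc(S(N)(=O)=O)cc2)C2=C(C(=O)CCC2)C1c1ccco1` differs from compound 2 in one place: furan-2-yl in place of 4-nitrophenyl on a saturated ring carbon. Among the compounds with values here, the one measured step, a number 70 percentage points higher from compound 1 to compound 2 (beyond the scatter), concerns a different exchange at the same saturated ring carbon and shows that this position can move the read-out strongly. Within the data shown here, no step involves furan-2-yl, so the direction for compound 3 is uncertain; a decrease of moderate size is expected, a number 40 percentage points lower from compound 2 to compound 3 (beyond the scatter). Compound 3 is estimated at 40%, within 10% to 75%.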

Compound 3, a percentage reported as activity, at one concentration (the size of the read-out at that concentration, not a potency): 0%
Estimate against measurement, compound 3: 40 percentage points above, and the stated range ends above it.
By their numbers in this assay, from the lowest: compounds 3 and 1 (each within the scatter of the next); then compound 2.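

In this assay furan-2-yl in place of 4-nitrophenyl gives a number 80 percentage points lower from compound 2 to compound 3 (beyond the scatter) and shows that not every aromatic ring on this saturated ring carbon keeps a high read-out. Against 2-phenylethenyl, furan-2-yl gives a number 10 percentage points lower from compound 1 to compound 3 (within the scatter) and no difference can be claimed, so of these three groups only 4-nitrophenyl stands apart. Nothing at hand explains this result. On these data alone, it remains open whether a plain phenyl ring at this carbon would keep the read-out of compound 2. The same holds for a 4-aminophenyl or a 4-carboxyphenyl ring.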